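Quinuclidine triazole series: resolving the undefined stereocentre

The source may hold more compounds than are shown below. What is called first, only, known or untested is meant among the compounds shown, and "the series" means these compounds.

Compound 2 `Oc1ccc(-c2cn(C3CN4CCC3CC4)nn2)cc1` gives 627 nM in an assay on HEK293 cells for displacement of a labelled ligand from Neuronal acetylcholine receptor; alpha4/beta2 (Homo sapiens), read by scintillation counting, with a stated time of 120 min; on this read-out higher numbers stand for weaker inhibition and lower numbers for stronger inhibition. Among the two numbers so far it sits alongside compound 1 `Oc1ccc(-c2cn([C@@H]3CN4CCC3CC4)nn2)cc1`, which gives 461 nM in the same assay; the step of a 1.4-fold higher number from compound 1 to compound 2 (0.13 log units; within the scatter) stays within the scatter. Compound 3 `Oc1ccc(-c2cn([C@H]3CN4CCC3CC4)nn2)cc1` differs from compound 2 as follows: the two compounds have the same atoms and bonds; at least one stereo element is drawn with a configuration in one of them and without one in the other: 1 of 3 stereo elements differ; a stereocentre at a saturated ring carbon is drawn without a configuration in compound 2 and R in compound 3. Going by the values given here, the only step that bears on it is the one from compound 1 to compound 2, and it was small, so for compound 3 a step of a 1.4-fold higher number from compound 2 to compound 3 (0.16 log units; within the scatter) towards a higher number is expected, modest in size. Compound 3 is therefore estimated at 900 nM, within 350 nM to 2500 nM.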

Compound 3, inhibition constant: 7390 nM
Compound 3: the middle estimate sits 8.2-fold (0.91 log units) below what was measured; measured number above the stated range.
By their numbers in this assay, from the lowest: compounds 1 and 2 (each within the scatter of the next); then compound 3.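

At the saturated ring carbon, configuration clearly matters in this assay, which the earlier pair could not show: the change from S to R gives a 16-fold higher number from compound 1 to compound 3 (1.20 log units; beyond the scatter). The form drawn without a configuration lies on the S side of this gap, with a 12-fold higher number from compound 2 to compound 3 (1.07 log units; beyond the scatter). That last step is read against a drawing left undefined at this carbon: the fact that one of compounds 2 and 3 is drawn with a defined configuration and the other without, at the place where they differ

Going by these compounds, whether the advantage of the S form holds when an amine or a carboxylic acid replaces the hydroxyl stays open. On these data alone, the composition of the undefined material also stays open.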